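The source may report more compounds than this note shows. Statements on the series, on what has been measured and on what is new or still open speak of the compounds shown alone.

Compound 1 `Cc1ccc(S(=O)(=O)N2CCN(c3ncc(C(=O)NO)s3)CC2)cc1`: 350 nM
Compound 2 `Cc1ccc(S(=O)(=O)N2CCN(c3ncc(/C=C/C(=O)NO)s3)CC2)cc1`: 2000 nM

In a functional assay on MCF7 cells (Homo sapiens) for antiproliferative activity (on this read-out lower numbers stand for stronger inhibition of growth and higher numbers for weaker inhibition of growth), compound 2 gives the highest of the two numbers. Among the measured compounds shown here, the only measured step was a 5.7-fold higher number from compound 1 to compound 2 (0.76 log units; beyond the scatter), which lies beyond the scatter and leaves compound 2 with the weaker inhibition. Compound 3 `O=C(/C=C/c1cnc(N2CCN(S(=O)(=O)c3ccccc3)CC2)s1)NO` differs from compound 2 by hydrogen in place of methyl on an aromatic carbon, the same difference cut one bond further out reading 4-methylphenyl to phenyl. For the measured compounds named here, no measured step touches this change, since the one available step concerns a different part of the molecule. Compound 3 is therefore expected to stay close to compound 2, with a step of no change at the digits printed from compound 2 to compound 3 (within the scatter) within the scatter. The estimate for compound 3 is 2000 nM, ranging from 800 nM to 5000 nM.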

Compound 3, concentration for 50% growth inhibition: 3000 nM
Beside the measured number, compound 3's estimate is 1.5-fold (0.18 log units) below it; low and high end bracket the measured number.
By their numbers in this assay, from the lowest: compound 1; then compounds 2 and 3 (each within the scatter of the next).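

In this assay, replacing methyl with hydrogen on the aromatic carbon gives a 1.5-fold higher number from compound 2 to compound 3 (0.18 log units; within the scatter) and so the two compounds cannot be told apart. Among the compounds shown here, this is the first measured change at this position, since the earlier step concerned a different part of the molecule. No measurement shown here gives a reason for this result.

From the compounds shown here alone, whether a methoxy group, a chlorine atom or an amine at this position would shift the number remains open. So does whether this change would give a similar result on compound 1.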